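Ethoxycarbonyl to benzyloxycarbonyl on compound 2

The compounds below may be only part of what the source reports. "The series", "measured", "known", "first", "only" and "open" are said of these compounds alone.

compound 1 `COc1ccc(C2=NN(C(=O)OCc3ccccc3)C(c3cc(OC)c(OC)c(OC)c3)C2)cc1` gives > 10000 nM (a limit)
compound 2 `CCOC(=O)N1N=C(c2cccc(O)c2)CC1c1cc(OC)c(OC)c(OC)c1` gives 4710 nM

Among the compounds with values here, both values come from a functional assay on MDA-MB-231 cells (Homo sapiens) for antiproliferative activity, read by MTT assay, with a stated time of 48 h (a higher number here means a weaker inhibitor of growth, a lower number a stronger inhibitor of growth), where compound 2 holds the only actual number so far. Compound 1 also carries benzyloxycarbonyl, and its > 10000 nM is a limit of the assay. Compound 3 `COc1cc(C2CC(c3cccc(O)c3)=NN2C(=O)OCc2ccccc2)cc(OC)c1OC` has phenyl in place of methyl on a saturated chain carbon bound to an oxygen next to a carbonyl group. Within the data shown here, no measured step shows this change in isolation. In this assay, little beyond the scatter is expected, with any shift towards weaker growth inhibition. The expected change is a 1.5-fold higher number from compound 2 to compound 3 (0.17 log units; within the scatter). For compound 3 the estimated value is 7000 nM, within an expected range of 2000 nM to 25000 nM.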

Compound 3, concentration for 50% growth inhibition: > 10000 nM
Compound 3 ended at the assay's limit (the forecaster's own chance of this, stated with the estimate: 35%); middle value at least 1.4-fold (0.15 log units) from the limit.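

In this assay, phenyl in place of methyl on a saturated chain carbon bound to an oxygen next to a carbonyl group gives an at least 2.1-fold higher number from compound 2 to compound 3 (0.32 log units; beyond the scatter). Within the data shown here, this is the first readable step, and it shows that the ethoxycarbonyl compound holds more growth inhibition than its benzyloxycarbonyl partner. Its full size stays hidden: the limit of > 10000 nM in this assay, at which 2 of the 3 values shown sit.

The step between the two limits, which also carries 3-hydroxyphenyl in place of 4-methoxyphenyl, cannot be read. Open, on these data alone, is how a propyl chain or an aminoethyl group would read at this position.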